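The source may report more compounds than this note shows. Statements on the series, on what has been measured and on what is new or still open speak of the compounds shown alone.

Of the compounds shown here, three of one series have been tested in a functional assay on the whole organism (liver, strain NMRI) for inhibition, with Mus musculus as the target, with a stated time of 3 h, at a dose of 3 mg/kg by the oral route; on this read-out lower numbers stand for less inhibition and higher numbers for more inhibition at the one dose given (going by the name of the read-out). Compound 1 `O=[N+]([O-])c1cc(-c2nc(-c3ccccc3)no2)cc(O)c1O` gives 20.6%. Compound 2 `O=[N+]([O-])c1cc(-c2nc(-c3ccc(Cl)c(Cl)c3)no2)cc(O)c1O` gives 8.8%. Compound 3 `O=[N+]([O-])c1cc(-c2nc(-c3ccc(Br)cc3)no2)cc(O)c1O` gives 12.7%. For the measured compounds named here, on these numbers compound 3 lies between the other two, and neither gap reaches beyond the scatter: the step of a number 7.9 percentage points lower from compound 1 to compound 3 (within the scatter) and the step of a number 3.9 percentage points higher from compound 2 to compound 3 (within the scatter) are both within it, while only the step of a number 11.8 percentage points lower from compound 1 to compound 2 (beyond the scatter) is a modest one.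

Compound 4 `Cc1nc(-c2noc(-c3cc(O)c(O)c([N+](=O)[O-])c3)n2)cs1` has not yet been measured in this assay. It differs from compound 3 by 2-methyl-1,3-thiazol-4-yl in place of 4-bromophenyl on an aromatic carbon. Two of the measured steps bear on this change, both on the same aromatic carbon of the shared core: the step of a number 7.9 percentage points lower from compound 1 to compound 3 (within the scatter) and the step of a number 3.9 percentage points higher from compound 2 to compound 3 (within the scatter), each within the scatter. Going by the values given here, no measured step replaces a six-membered carbon ring by a five-membered ring with two hetero atoms, so the change is untested here. The expected step is therefore one within the scatter, a number 0.7 percentage points lower from compound 3 to compound 4 (within the scatter). Compound 4 is estimated at 12%, with a range from 2% to 25%.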

Compound 4, a percentage reported as inhibition, in the whole organism at one dose (the size of the read-out at that dose, not a potency): 22.9%
Compound 4: the middle estimate sits 10.9 percentage points below what was measured; measured number inside the range.
By their numbers in this assay, from the lowest: compounds 2, 3, 1 and 4 (each within the scatter of the next, the first and the last beyond it).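

In this assay, the 2-methyl-1,3-thiazol-4-yl group, on the aromatic carbon between two ring nitrogen atoms, gives the first rise at this position, with a step of a number 10.2 percentage points higher from compound 3 to compound 4 (beyond the scatter) and another a number 14.1 percentage points higher from compound 2 to compound 4 (beyond the scatter), both beyond the scatter, so a five-membered aromatic ring with 2 hetero atoms is accepted here without loss against either halogenated phenyl group. Against the plain phenyl group the change shows no such rise, with a step of a number 2.3 percentage points higher from compound 1 to compound 4 (within the scatter) that stays within the scatter, so compound 1 and compound 4 cannot be told apart. No measurement at hand on any property of these groups accounts for these steps.

The compounds shown leave open how much of this result rests on the methyl group of the new ring. They also leave open how an amine, a carboxylic acid or a longer alkyl chain would fare at this position.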